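Two measured diacylhydrazides and one awaiting its number

The source may hold more compounds than are shown below. What is called first, only, known or untested is meant among the compounds shown, and "the series" means these compounds.

Compound 1 `Cc1ccccc1C(=O)N(NC(=O)c1ccccc1)C(C)(C)C`: 224 nM
Compound 2 `CC(C)(C)N(NC(=O)c1cccc(C#N)c1)C(=O)c1ccccc1Cl`: 955 nM

Both compounds were tested in an assay on cells for agonist activity at ecdysone receptor (Bombyx mori), read by a luciferase reporter, with a stated time of 24 h; on this read-out higher numbers stand for an effect only at larger amounts of compound and lower numbers for an effect already at smaller amounts. Compound 1 gives 224 nM there, while compound 2 gives 955 nM, the higher of the two numbers, so compound 2 needs the larger amount to act and the gap between them lies beyond the usual scatter.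

The next compound, compound 3 `Cc1ccc(C)c(C(=O)NN(C(=O)c2ccccc2Cl)C(C)(C)C)c1`, differs from compound 2 in a single place: 2,5-dimethylphenyl in place of 3-cyanophenyl on a carbonyl carbon. The rest of the molecule, including the chloro-bearing ring on the other carbonyl, is kept.

For the measured compounds named here, no pair with exactly this exchange has been measured, so the step from compound 2 to compound 3 in this assay is estimated rather than known. Compound 3 is expected to give about 320 nM, within a range of 80 nM to 1300 nM, which would mean an estimated step of a 3.0-fold lower number from compound 2 to compound 3 (0.47 log units; beyond the scatter) toward a lower number, modest in size.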

Compound 3, half-maximal effective concentration: 1620 nM
For compound 3 the middle estimate is 5.1-fold (0.70 log units) below the measured one; measured number outside the range, above it.
By their numbers in this assay, from the lowest: compound 1; then compounds 2 and 3 (each within the scatter of the next).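

In this assay, the exchange of 3-cyanophenyl for 2,5-dimethylphenyl on a carbonyl carbon gives a 1.7-fold higher number from compound 2 to compound 3 (0.23 log units; within the scatter), so this assay cannot tell these two rings apart when the chloro-bearing ring on the other carbonyl is kept. For the compounds shown here, this is the first look at a single change at this position, and it shows that a ring with a nitrile and a ring with only carbon substituents can give numbers that do not differ beyond normal repeat variation. Nothing available explains this outcome.

The compounds shown leave open whether any group at this position can shift the number beyond the scatter. A phenyl ring bearing an amine or a carboxylic acid, for example, could answer that question.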